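A few compounds are considered here, and "the series" means these few. Any claim that something is new, unique, unknown or untested is made for them only; others in the source may bear on it.

Working notes on the series.

The shared core is that of compound 1 `CNC(=O)c1ccc(Oc2cccc(NC(=S)Nc3ccc(F)c(Cl)c3)c2)nc1`, which in a functional assay on HepG2 cells (Homo sapiens) for antiproliferative activity, read by MTT assay (on this read-out lower numbers stand for stronger inhibition and higher numbers for weaker inhibition), gives only the assay limit > 100000 nM. Compound 2 `CNC(=O)c1ccc(Oc2cccc(NC(=S)Nc3cccc(C(F)(F)F)c3)c2)nc1` in this assay gives 23300 nM. Among the measured compounds shown here, the only measured step is an at least 4.2-fold lower number from compound 1 to compound 2 (0.63 log units; beyond the scatter), and one of the two values shown sits at the limit of > 100000 nM in this assay, at which 1 of the 2 values shown sits. Compound 2 thus stands at the only number shown; the other value is a limit.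

Compound 3 `CNC(=O)c1ccc(Oc2cccc(NC(=S)Nc3ccc(C)cc3)c2)nc1` differs from compound 2 by 4-methylphenyl in place of 3-(trifluoromethyl)phenyl on an amide-type nitrogen. For the measured compounds named here, the single measured step, which put a 3-(trifluoromethyl)phenyl in place of another substituted phenyl on the same amide-type nitrogen and gave an at least modest gain, bears on this change only loosely, as the 3-(trifluoromethyl)phenyl is now removed again. The expectation for compound 3 in this assay is a step of a 1.9-fold higher number from compound 2 to compound 3 (0.29 log units; within the scatter) towards a higher number, possibly beyond the scatter. Compound 3 is estimated at 45000 nM, with a range from 15000 nM to 130000 nM.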

Compound 3, half-maximal inhibitory concentration: 65400 nM
Estimate against measurement, compound 3: 1.5-fold (0.16 log units) below, and the stated range covers the measured number.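

On the amide-type nitrogen, 4-methylphenyl in place of 3-(trifluoromethyl)phenyl gives a 2.8-fold higher number from compound 2 to compound 3 (0.45 log units; beyond the scatter) in this assay, so 3-(trifluoromethyl)phenyl now compares favourably with a second group and not only with the 3-chloro-4-fluorophenyl. Compound 2 therefore holds the lowest number of the three, with its steps to both others beyond the scatter. The other new step, an at least 1.5-fold lower number from compound 1 to compound 3 (0.18 log units; that floor lies within the scatter), does not order the remaining two groups, as it rests on a limit: the limit of > 100000 nM in this assay, at which 1 of the 3 values shown sits.

The step from 3-(trifluoromethyl)phenyl to 4-methylphenyl changes both the substituent and its place on the phenyl ring, so the compounds shown do not separate the two, a question that 3-methylphenyl or 4-(trifluoromethyl)phenyl would address. Also open, as far as these compounds go, is how this nitrogen responds to a cyclohexyl group, or to a phenyl ring carrying an amine or a carboxylic acid.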